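Cytotoxicity Limits Across Three Measured Analogues and One Untested

The source may hold more compounds than are shown below. What is called first, only, known or untested is meant among the compounds shown, and "the series" means these compounds.

- Compound 1, `COc1cc2c(cc1OC)CN(S(=O)(=O)c1ccc(-n3cc(COc4ccc(C=O)cc4)nn3)cc1)CC2`, gives > 50 ug/mL in an ADME assay on Vero cells (Chlorocebus sabaeus) for cytotoxicity, with a stated time of 4 days (on this read-out lower numbers stand for stronger inhibition and higher numbers for weaker inhibition), a value that is a limit of the assay, not a number.
- Compound 2, `COc1cc2c(cc1OC)CN(S(=O)(=O)c1ccc(-n3cc(COc4ccc([N+](=O)[O-])cc4)nn3)cc1)CC2`, gives > 50 ug/mL in this assay, likewise only a limit.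
- Compound 3, `COc1cc2c(cc1OC)CN(S(=O)(=O)c1ccc(-n3cc(COc4ccc5ccccc5c4)nn3)cc1)CC2`, gives > 50 ug/mL in this assay, again only a limit.

Compound 3 therefore stands at the same ceiling as its two companions: all three sit at the limit of > 50 ug/mL in this assay, at which 3 of the 3 values shown sit, so none can be ranked against another. The measured steps reflect this. The change from compound 1 to compound 2 reads a step that the two limits leave unreadable from compound 1 to compound 2, the change from compound 1 to compound 3 reads a step that the two limits leave unreadable from compound 1 to compound 3, and the change from compound 2 to compound 3 reads a step that the two limits leave unreadable from compound 2 to compound 3.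

Compound 4, `COc1cc2c(cc1OC)CN(S(=O)(=O)c1ccc(-n3cc(COc4ccc(C)cc4)nn3)cc1)CC2`, has not been measured. It differs from compound 3 by 4-methylphenyl in place of naphthalen-2-yl on an oxygen on a saturated carbon. Every comparable swap at this oxygen left the read-out at the limit, so no direction of change can be read, and no step beyond the scatter is expected; compound 4 is expected to show a number no higher from compound 3 to compound 4 (the limit leaves the size open). Compound 4 is therefore estimated at 50 ug/mL, within a range from 25 ug/mL to 100 ug/mL, most likely reported again only as a limit.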

Compound 4, half-maximal inhibitory concentration: > 50 ug/mL
Compound 4 was reported as a limit (the forecaster's own chance of this, stated with the estimate: 85%); the middle value lies on the limit itself.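

In this assay compound 4 gives > 50 ug/mL, which is a limit of the assay and not a number. No step from compound 1, compound 2 or compound 3 to compound 4 can therefore be read, because all four compounds share one ceiling: the limit of > 50 ug/mL in this assay, at which 4 of the 4 values shown sit.

The compounds shown leave open where each true value lies, and so whether the groups on the oxygen differ in cytotoxicity at all.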